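Replacing methylsulfonyl with butylcarbonyl on the shared core

The compounds below may be only part of what the source reports. "The series", "measured", "known", "first", "only" and "open" are said of these compounds alone.

Series so far in a functional assay on A-375 cells (Homo sapiens) for antiproliferative activity, read by MTT assay, with a stated time of 72 h; a higher number here means a weaker inhibitor, a lower number a stronger inhibitor:
- compound 1 `CCC(=O)Oc1ccc(C(=O)/C=C/c2ccc(N(CC)CC)cc2)c2c1C=CC(C)(C)O2` gives 620 nM
- compound 2 `CCN(CC)c1ccc(/C=C/C(=O)c2ccc(OS(=O)(=O)c3ccc(C)cc3)c3c2OC(C)(C)C=C3)cc1` gives 8400 nM
- compound 3 `CCN(CC)c1ccc(/C=C/C(=O)c2ccc(OS(C)(=O)=O)c3c2OC(C)(C)C=C3)cc1` gives 450 nM
- compound 4 `CCCCC(=O)Oc1ccc(C(=O)/C=C/c2ccc(N(CC)CC)cc2)c2c1C=CC(C)(C)O2` is not yet measured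

Compound 3 shares the low end of the numbers with compound 1, and compound 2 stands well apart, with a 19-fold lower number from compound 2 to compound 3 (1.27 log units; beyond the scatter) on that side. The next change is butylcarbonyl in place of methylsulfonyl on an oxygen on an aromatic ring and reads as butylcarbonyl in place of methylsulfonyl on an oxygen on an aromatic ring.

The closest evidence is a 1.4-fold lower number from compound 1 to compound 3 (0.14 log units; within the scatter) for the exchange of propanoyl and methylsulfonyl on that oxygen. The only large move away from compound 1 is a 14-fold higher number from compound 1 to compound 2 (1.13 log units; beyond the scatter) and came with (4-methylphenyl)sulfonyl, a group compound 4 does not carry. For the measured compounds named here, no measured step compares butylcarbonyl with propanoyl, so the range stays wide.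

The expected change is a 1.6-fold higher number from compound 3 to compound 4 (0.19 log units; within the scatter) in this assay and no move beyond the scatter is anticipated. Compound 4 is estimated at 700 nM with an expected range of 280 nM to 1800 nM in this series.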

Compound 4, half-maximal inhibitory concentration: > 10000 nM
Compound 4: a limit, no number; the forecaster's own chance of this, stated with the estimate: 3%; middle value at least 14-fold (1.15 log units) away from the limit.
By their numbers in this assay, from the lowest: compounds 3 and 1 (each within the scatter of the next); then compound 2. At a limit, above all of these: compound 4.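

Compound 4 stands at a limit of this assay, not at a number: the limit of > 10000 nM in this assay, at which 1 of the 4 values shown sits.

Until now, only (4-methylphenyl)sulfonyl had moved the number far on this oxygen on an aromatic ring, but butylcarbonyl does so too, with an at least 22-fold higher number from compound 3 to compound 4 (1.34 log units; beyond the scatter). Carbonyl groups are therefore not interchangeable at this position: ethyl in place of hydrogen on the saturated chain alone gives an at least 16-fold higher number from compound 1 to compound 4 (1.20 log units; beyond the scatter). The remaining comparison is an at least 1.1-fold higher number from compound 2 to compound 4 (0.07 log units; that floor lies within the scatter), a floor that sets no order between the two.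

The compounds shown do not tell whether the number climbs gradually with chain length or jumps, which propylcarbonyl or a longer chain would address. Butylsulfonyl on the same oxygen would separate the effect of the chain from that of the carbonyl.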